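One ring swap on the carbonyl carbon of compound 3

A few compounds are considered here, and "the series" means these few. Any claim that something is new, unique, unknown or untested is made for them only; others in the source may bear on it.

The measured compounds, each tested in a functional assay on MCF7 cells (Homo sapiens) for antiproliferative activity, read by sulforhodamine B assay, with a stated time of 72 h, tested at 10 uM; a lower number here means a stronger effect, a higher number a weaker effect of the compound at the concentration tested:
Compound 1, `COc1cc(Br)cc(/C=C/C(=O)c2ccc(Cl)cc2)c1O`, gives 53.3%.
Compound 2, `O=C(/C=C/c1cc(Br)ccc1O)c1ccc(Br)cc1`, gives 28.7%.
Compound 3, `COC(=O)C1=C(N)Oc2c(OC)cc(Br)cc2C1CC(=O)c1ccc(Cl)cc1`, gives 80.3%.

Among these three numbers compound 3 stands highest, which in this assay means the weakest effect at the tested concentration. The nearest is compound 1, whose number is lower by a gap beyond the scatter, and the furthest is compound 2, whose number is lower by a gap that is also beyond the scatter. Among the compounds with values here, compound 3 differs from the other two in its core, so none of these pairs is a change in a single place, and no step between measured compounds is available to lean on.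

Compound 4, `COC(=O)C1=C(N)Oc2c(OC)cc(Br)cc2C1CC(=O)c1cccc(OC)c1`, keeps the core of compound 3 and changes one place: 3-methoxyphenyl in place of 4-chlorophenyl on a carbonyl carbon. Within the data shown here, no measured pair shows what such an exchange does on this core. An exchange of this kind is expected to move this assay by little, possibly staying within the scatter, in either direction. For compound 4 the expected value is 82%, in a range from 65% to 98%. The expected step of a number 1.7 percentage points higher from compound 3 to compound 4 (within the scatter) is small.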

Compound 4, a percentage reported as activity, at one concentration (the size of the read-out at that concentration, not a potency): 142%
Beside the measured number, compound 4's estimate is 60 percentage points below it; measured number above the stated range.
By their numbers in this assay, from the lowest: compound 2; then compound 1; then compound 3; then compound 4.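

In this assay, putting 3-methoxyphenyl in place of 4-chlorophenyl on a carbonyl carbon gives a number 61.7 percentage points higher from compound 3 to compound 4 (beyond the scatter) on an otherwise unchanged core. Compounds 1 and 2 differ from compound 3 in their core, so they could not show that this place alone can move the read-out so far. Since a higher number means a weaker effect, compound 4 acts more weakly than compound 3 at the tested concentration, which shows that this ring exchange is far from neutral on this core, though nothing available explains why the number moves this much.

This one exchange removes the chlorine, brings in a methoxy group and changes the ring position of the substituent all at once, so the compounds shown cannot say which of these changes matters. Unsubstituted phenyl, 4-methoxyphenyl or 3-chlorophenyl on the same carbonyl carbon would separate these changes, while an amine or a carboxylic acid on that ring would show whether a very different group is tolerated there.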